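The source may hold more compounds than are shown below. What is called first, only, known or untested is meant among the compounds shown, and "the series" means these compounds.

Compound 2 `CCOC(=O)C1=C(C)NC(C)=C(C(=O)OC)C1c1[nH]cnc1Cl` is one of three compounds built on the shared core, alongside compound 1 `COC(=O)C1=C(C)NC(C)=C(C(=O)OC)C1c1[nH]cnc1Cl` and compound 3 `COC(=O)C1=C(C)NC(C)=C(C(=O)OCCc2ccccc2)C1c1[nH]cnc1Cl`. In an assay on isolated protein for inhibition of Voltage-dependent L-type calcium channel subunit alpha-1C (Cavia porcellus) (a lower number here means a stronger inhibitor, a higher number a weaker inhibitor), compound 1 gives 1200 nM, compound 2 gives 661 nM and compound 3 gives 79.4 nM, so compound 2 holds the second highest of the three numbers, closest to compound 1 and furthest from compound 3. The change to compound 4 `CCOC(=O)C1=C(C)NC(C)=C(C(=O)OCC2CCCCC2)C1c1[nH]cnc1Cl` is cyclohexyl in place of hydrogen on a saturated chain carbon bound to an oxygen next to a carbonyl group. Among the measured compounds shown here, two steps bear on it: a 15-fold lower number from compound 1 to compound 3 (1.18 log units; beyond the scatter) and an 8.3-fold lower number from compound 2 to compound 3 (0.92 log units; beyond the scatter), both beyond the scatter, while a 1.8-fold lower number from compound 1 to compound 2 (0.26 log units; within the scatter) lies within it. A larger group at this place is therefore expected to lower the number in this assay, by about a 5.1-fold lower number from compound 2 to compound 4 (0.71 log units; beyond the scatter). Compound 4 is estimated at 130 nM, with a range from 40 nM to 400 nM.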

Compound 4, half-maximal inhibitory concentration: 513 nM
The estimate for compound 4 lay 3.9-fold (0.60 log units) below the measured number; measured number above the stated range.
By their numbers in this assay, from the lowest: compound 3; then compounds 4, 2 and 1 (each within the scatter of the next, the first and the last beyond it).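

In this assay the step with cyclohexyl at this place is a 1.3-fold lower number from compound 2 to compound 4 (0.11 log units; within the scatter) and stays within the scatter, whereas benzyl at the same place gives a 15-fold lower number from compound 1 to compound 3 (1.18 log units; beyond the scatter) on a different starting compound. Group size alone therefore does not account for the change at this place across these compounds, and a ring of carbon only need not bring a large step. No evidence given here explains this difference. On these data alone, it remains open whether benzyl would give a similar step from compound 2, and how an amine or a longer chain ending in cyclohexyl would behave at this place.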